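The source may report more compounds than this note shows. Statements on the series, on what has been measured and on what is new or still open speak of the compounds shown alone.

For the measured compounds named here, in a functional assay for inhibition, with Rattus norvegicus as the target (a lower number here means a stronger inhibitor, a higher number a weaker inhibitor), compound 1 `CCOC(=O)c1c(CC)c(OC)c2ccccc2c1OC(C)=O` gives 3760 nM, the second highest of the three numbers measured so far. Compound 2 `CCCCCc1c(C(=O)OCC)c(OC(C)=O)c2ccccc2c1OC` gives 8920 nM, the highest of the three. Compound 3 `CCCCc1c(C)c(OC)c2ccccc2c1OC(C)=O` gives 200 nM, the lowest of the three.

The next compound, compound 4 `CCc1c(CC)c(OC(C)=O)c2ccccc2c1OC`, has ethyl in place of ethoxycarbonyl on an aromatic carbon.

Going by the values given here, only one measured step links two compounds that differ in a single place, a 2.4-fold higher number from compound 1 to compound 2 (0.38 log units; beyond the scatter). That step is modest, and it comes from propyl in place of hydrogen on a saturated chain carbon, so the ethoxycarbonyl stays untouched. Among the compounds with values here, no measured step removes the ethoxycarbonyl, which leaves the expectation on thin ground.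

The best available hint is compound 3, which also has no ethoxycarbonyl and gives 200 nM, well under the two compounds that carry the group. Compound 3 differs from compound 4 in other places too, so it serves only as a rough guide. A sizeable move towards a lower number is therefore expected, and the estimated change is an 8.4-fold lower number from compound 1 to compound 4 (0.92 log units; beyond the scatter). For compound 4 the expected value is 450 nM, with an estimated range from 120 nM to 2000 nM.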

Compound 4, half-maximal inhibitory concentration: 400 nM
The estimate for compound 4 lay 1.1-fold (0.05 log units) above the measured number; measured number inside the range.
By their numbers in this assay, from the lowest: compounds 3 and 4 (each within the scatter of the next); then compound 1; then compound 2.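

In this assay, for the compounds shown here, the first direct reading of this position comes from replacing ethoxycarbonyl with ethyl on the aromatic carbon ortho to an acetoxy group, which gives a 9.4-fold lower number from compound 1 to compound 4 (0.97 log units; beyond the scatter). The ester is therefore not needed for inhibition at this level on the core of compound 1, and the number falls clearly once it is gone. The swap changes several things at once, going from 5 heavy atoms and 2 hydrogen-bond acceptors to 2 heavy atoms and no acceptors, and no measurement shown here explains the drop or separates these changes.

From the compounds shown here alone, it remains open whether a carboxylic acid or a primary amide on this aromatic carbon would give a number closer to that of compound 1 or of compound 4, which would help show whether the carbonyl itself or the whole size of the ester goes with the weaker inhibition. Going by these compounds, it is also open whether the same replacement would give a step of similar size on compound 2, which carries a longer chain.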